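A few compounds are considered here, and "the series" means these few. Any claim that something is new, unique, unknown or untested is made for them only; others in the source may bear on it.

In a functional assay on B16-F10 cells (Mus musculus) for antiproliferative activity, read by MTT assay, with a stated time of 48 h (on this read-out lower numbers stand for stronger inhibition and higher numbers for weaker inhibition), compound 1 (`COc1ccc(/C=C/c2cc(OC)cc(OC)c2/C=C/C(=O)c2ccc(C)cc2)cc1`), which carries a 4-methylphenyl on its carbonyl carbon, gives 5.3 ug/mL. Compound 2 (`COc1ccc(/C=C/c2cc(OC)cc(OC)c2/C=C/C(=O)c2ccccc2C)cc1`), with a 2-methylphenyl in that place, gives 6.1 ug/mL. Going by the values given here, the measured step is a 1.2-fold higher number from compound 1 to compound 2 (0.06 log units; within the scatter), so compound 2 stands level with compound 1, the only other compound measured so far.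

Compound 3 (`COc1ccc(/C=C/c2cc(OC)cc(OC)c2/C=C/C(=O)c2ccc(C)cc2C)cc1`) keeps the 2-methylphenyl of compound 2 and turns it into a 2,4-dimethylphenyl, with methyl in place of hydrogen on an aromatic carbon. The new methyl sits meta to a methyl group and para to a large group.

Among the compounds with values here, the one measured step bears on this only indirectly, as it relocates a methyl group rather than adding one. Within the data shown here, no measured pair shows what an added methyl does. Compound 3 unites the two methyl placements seen singly in the measured pair, and those two placements gave values within the scatter of each other. No change beyond the scatter is therefore expected in this assay, and no direction can be favoured. The expected step is a 1.1-fold lower number from compound 2 to compound 3 (0.04 log units; within the scatter). Compound 3 is estimated at 5.5 ug/mL, with an expected range from 3 ug/mL to 10 ug/mL.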

Compound 3, half-maximal inhibitory concentration: 4 ug/mL
Compound 3: middle estimate off by 1.4-fold (0.14 log units), on the high side, and the stated range covers the measured number.
By their numbers in this assay, from the lowest: compounds 3, 1 and 2 (each within the scatter of the next).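

In this assay compound 3 shows what adding a methyl does, where the earlier pair showed only a methyl relocated: turning the 2-methylphenyl into a 2,4-dimethylphenyl gives a 1.5-fold lower number from compound 2 to compound 3 (0.18 log units; within the scatter) and reaching the same group from the 4-methylphenyl gives a 1.3-fold lower number from compound 1 to compound 3 (0.12 log units; within the scatter) as well. Both steps lie within the scatter, so whichever of the two single methyl groups the new one joins, the added methyl does not separate compound 3 from compound 1 or compound 2, and all three stand level on this read-out. Nothing at hand offers an explanation for this result.

All three compounds carry only methyl groups on this aromatic ring, so these values leave open whether the ring tolerates substituents in general or only groups as small as methyl, and how a plain phenyl without any methyl would compare. An amine, a carboxylic acid, a chlorine atom or a longer chain such as butyl at these places could behave quite differently, and the flat result for methyl says nothing about any of them.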